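The compounds below may be only part of what the source reports. "The series", "measured", "known", "first", "only" and "open" are said of these compounds alone.

Measured so far in a functional assay on HepG2 cells (Homo sapiens) for antiproliferative activity, read by MTT assay, with a stated time of 48 h; a lower number here means a stronger inhibitor, a higher number a weaker inhibitor:
compound 1 `Cc1ccc(-c2nc3ccc(Cl)cc3c(=O)[nH]2)cc1`: 9.86 ug/mL
compound 2 `Cc1ccc(-c2nc3ccc(Cl)cc3c(=O)n2N)cc1`: 18.4 ug/mL
compound 3 `CSc1nc(-c2ccc(C)cc2)nc2ccc(Cl)cc12`: 13.3 ug/mL

Compound 3 stands second highest of the three numbers; its gap to compound 1 and its gap to compound 2 both lie within the scatter, so the three compounds read alike on what has been measured. Among the compounds with values here, the one measured step, a 1.9-fold higher number from compound 1 to compound 2 (0.27 log units; within the scatter), is also within the scatter; it changes the substituent on an aromatic nitrogen and says nothing direct about the sulfur chain. Compound 4 `Cc1ccc(-c2nc(SCC(=O)Nc3ccc(F)cc3)c3cc(Cl)ccc3n2)cc1` differs from compound 3 by (4-fluorophenyl)carbamoyl in place of hydrogen on a saturated chain carbon bound to a sulfur. Within the data shown here, no measured pair covers such an entry on the saturated chain carbon bound to a sulfur, and the only step on record, itself within the scatter, gives no ground to expect a move in this assay beyond the scatter. The step from compound 3 is therefore expected to be small, about a 1.3-fold lower number from compound 3 to compound 4 (0.12 log units; within the scatter). On these data alone, compound 4 is estimated at 10 ug/mL in this assay, with a range from 4 ug/mL to 30 ug/mL that is kept wide because the entering group is untested.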

Compound 4, half-maximal inhibitory concentration: 18.4 ug/mL
For compound 4 the middle estimate is 1.8-fold (0.26 log units) below the measured one; low and high end bracket the measured number.
By their numbers in this assay, from the lowest: compounds 1, 3, 2 and 4 (each within the scatter of the next).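

Within the data shown here, the step of a 1.4-fold higher number from compound 3 to compound 4 (0.14 log units; within the scatter) in this assay gives the first reading at the saturated chain carbon bound to a sulfur. An entering (4-fluorophenyl)carbamoyl of 10 heavy atoms, with a six-membered aromatic ring of carbon only, 1 hydrogen-bond donor and 1 hydrogen-bond acceptor, therefore moves the number no further than the scatter at this position, on this one pair. No measurement at hand explains the size of this step.

On these data alone, whether the same holds for a different entering group stays open, for example an amine, a carboxylic acid or a longer alkyl chain in place of the (4-fluorophenyl)carbamoyl. The contribution of the fluorine also stays open, since the compounds shown hold no pair that isolates it.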